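Sulfonamide-linked anilinoquinazolines: ethyl for trifluoromethyl on the anilino ring

A few compounds are considered here, and "the series" means these few. Any claim that something is new, unique, unknown or untested is made for them only; others in the source may bear on it.

Two members of the series have been measured. Compound 1 `COc1cc2ncnc(Nc3cccc(Br)c3)c2cc1OCCCCC(=O)Nc1ccc(S(N)(=O)=O)cc1` gives 9750 nM in a functional assay on A-431 cells (Homo sapiens) for antiproliferative activity, read by MTT assay, with a stated time of 72 h; on this read-out lower numbers stand for stronger inhibition and higher numbers for weaker inhibition. Going by the values given here, compound 2 `COc1cc2ncnc(Nc3ccc(C(F)(F)F)cc3)c2cc1OCCCCC(=O)Nc1ccc(S(N)(=O)=O)cc1` gives 16900 nM in this assay; it holds the higher of the two numbers, but the only recorded step, a 1.7-fold higher number from compound 1 to compound 2 (0.24 log units; within the scatter), leaves the two compounds within the scatter of each other, so no ranking between them can be drawn.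

Compound 3 `CCc1ccc(Nc2ncnc3cc(OC)c(OCCCCC(=O)Nc4ccc(S(N)(=O)=O)cc4)cc23)cc1` keeps the whole of compound 2 except for one change: ethyl in place of trifluoromethyl on an aromatic carbon. Among the compounds with values here, no measured step touches this position on the anilino ring; the step from compound 1 to compound 2 exchanges the entire aryl group and is itself within the scatter. Nothing recorded therefore points to a shift beyond the scatter, and the expected step of a 1.2-fold lower number from compound 2 to compound 3 (0.08 log units; within the scatter) is set close to zero. For compound 3 the estimate in this assay is 14000 nM, with a range of 5000 nM to 40000 nM.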

Compound 3, half-maximal inhibitory concentration: 7220 nM
Beside the measured number, compound 3's estimate is 1.9-fold (0.29 log units) above it, and the stated range covers the measured number.
By their numbers in this assay, from the lowest: compounds 3, 1 and 2 (each within the scatter of the next, the first and the last beyond it).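

In this assay, ethyl in place of trifluoromethyl on this aromatic carbon, para to a large group, gives a 2.3-fold lower number from compound 2 to compound 3 (0.37 log units; beyond the scatter). Going by these compounds alone, this modest step is the first beyond the scatter, so a change at this position can register in the read-out. The exchange of the whole aryl group, a 1.4-fold lower number from compound 1 to compound 3 (0.13 log units; within the scatter), stays within the scatter, so 4-ethylphenyl and 3-bromophenyl cannot be ranked here. No measured data bear on what lies behind the ethyl and trifluoromethyl difference.

On these data alone, whether a longer chain such as propyl, an amine or a carboxylic acid on this carbon would extend the step or reverse it remains open. A single pair also leaves open whether the step holds on other parts of the series.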